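The source may report more compounds than this note shows. Statements on the series, on what has been measured and on what is new or still open speak of the compounds shown alone.

Two compounds have been measured in a functional assay on MCF7 cells (Homo sapiens) for antiproliferative activity, read by sulforhodamine B assay, with a stated time of 48 h; a higher number here means a weaker inhibitor, a lower number a stronger inhibitor:

compound 1, `COc1cc(C=C(C(=O)/C=C/c2cccc(OC)c2OC)C(=O)/C=C/c2cccc(OC)c2OC)ccc1O`, gives 480 nM
compound 2, `COc1cc(C=C(C(=O)/C=C/c2cccc(OC)c2OC)C(=O)/C=C/c2cccc(OC)c2OC)cc(Br)c1O`, gives 360 nM

Among these two numbers compound 1 has the highest, and its nearest neighbour is compound 2, the only other one; the step of a 1.3-fold lower number from compound 1 to compound 2 (0.12 log units; within the scatter) is within the scatter, so the two cannot be told apart.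

Compound 3, `COc1ccc(C=C(C(=O)/C=C/c2cccc(OC)c2OC)C(=O)/C=C/c2cccc(OC)c2OC)cc1O`, has not yet been measured. It differs from compound 1 in one place: 3-hydroxy-4-methoxyphenyl in place of 4-hydroxy-3-methoxyphenyl on a double-bonded chain carbon bound to a double-bonded chain carbon. The hydroxy and methoxy groups simply trade positions on that phenyl ring, so nothing is added or removed.

Among the measured compounds shown here, no measured step bears on this change. For the measured compounds named here, the only step in hand, from compound 1 to compound 2, concerns a bromo in place of hydrogen and says nothing about swapping the two oxygen-bearing groups. With no guidance in either direction, the expectation for this assay is a step of no size beyond the scatter, meaning a 1.0-fold higher number from compound 1 to compound 3 (0.02 log units; within the scatter). Compound 3 is therefore expected to give about 500 nM, with a range from 200 nM to 1300 nM.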

Compound 3, half-maximal inhibitory concentration: 310 nM
Beside the measured number, compound 3's estimate is 1.6-fold (0.21 log units) above it; measured number inside the range.
By their numbers in this assay, from the lowest: compounds 3, 2 and 1 (each within the scatter of the next).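

Swapping the two oxygen-bearing groups on this phenyl ring, 3-hydroxy-4-methoxyphenyl in place of 4-hydroxy-3-methoxyphenyl, gives in this assay a 1.5-fold lower number from compound 1 to compound 3 (0.19 log units; within the scatter) and so leaves the two arrangements indistinguishable in this core. The comparison with the brominated ring, 3-hydroxy-4-methoxyphenyl in place of 3-bromo-4-hydroxy-5-methoxyphenyl, gives a 1.2-fold lower number from compound 2 to compound 3 (0.06 log units; within the scatter) and likewise separates nothing, so all three phenyl groups on this double-bonded chain carbon now sit within the scatter of one another, and neither the arrangement of these groups nor the bromo gives a readable difference here. No supporting measurement is available to explain these small differences or to show whether they have any real meaning.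

Going by these compounds, these three compounds explore only a narrow range of groups on this ring, so it remains open whether an amine or a carboxylic acid in place of the hydroxy would move the number in this assay beyond the scatter. On these data alone, it is equally open whether a longer chain such as ethoxy in place of the methoxy would do so, or whether the ring needs either oxygen-bearing group at all.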